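Lengthening an Ether Chain on a Weak Inhibitor

The source may hold more compounds than are shown below. What is called first, only, known or untested is meant among the compounds shown, and "the series" means these compounds.

Going by the values given here, compound 2 `COc1ccc(NC(=O)CCCCCCCSc2nnc(Cc3nn(C)c(=O)c4ccccc34)n2C)cc1` is one of only two compounds measured in an assay on cells for inhibition of IL15-IL15 receptor (Homo sapiens), read by AlphaScreen, with stated times of 30 min and 1 h (a lower number here means a stronger inhibitor, a higher number a weaker inhibitor), where compound 2 gives 201000 nM. The other, compound 1 `Cn1c(Cc2nn(C)c(=O)c3ccccc23)nnc1SCCCCCCCC(=O)Nc1ccc(F)cc1F`, gives 110000 nM in this assay; the step of a 1.8-fold higher number from compound 1 to compound 2 (0.26 log units; within the scatter) exchanges the group on the amide nitrogen and does not separate the two beyond the scatter. Compound 3 `CCCOc1ccc(NC(=O)CCCCCCCSc2nnc(Cc3nn(C)c(=O)c4ccccc34)n2C)cc1` has not been measured yet. It differs from compound 2 by ethyl in place of hydrogen on a saturated chain carbon bound to an oxygen on an aromatic ring. Among the compounds with values here, no measured step touches this position; the only known step, a 1.8-fold higher number from compound 1 to compound 2 (0.26 log units; within the scatter), concerns a different part of the amide substituent and was itself small. With nothing pointing either way, compound 3 is expected to change little, and the expected step of a 1.0-fold lower number from compound 2 to compound 3 (0.00 log units; within the scatter) would stay within the scatter. The estimate for compound 3 in this assay is 200000 nM, with a range from 70000 nM to 600000 nM.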

Compound 3, half-maximal inhibitory concentration: 40000 nM
Beside the measured number, compound 3's estimate is 5.0-fold (0.70 log units) above it, and the stated range ends above it.
By their numbers in this assay, from the lowest: compound 3; then compounds 1 and 2 (each within the scatter of the next).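

In this assay, lengthening methoxy to propoxy gives a real change (a 5.0-fold lower number from compound 2 to compound 3 (0.70 log units; beyond the scatter)), showing that the saturated chain carbon bound to an oxygen on an aromatic ring is a place where added carbons can register, which the earlier pair could not show. The 4-propoxyphenyl group also separates from the 2,4-difluorophenyl group (a 2.8-fold lower number from compound 1 to compound 3 (0.44 log units; beyond the scatter)), whereas the 4-methoxyphenyl and 2,4-difluorophenyl compounds stayed within the scatter of each other, yet compound 3 at 40000 nM remains a weak inhibitor. No measurement at hand explains why the longer chain lowers the number.

Going by these compounds, whether a butoxy or hexyloxy group would lower the number further, or whether the trend stops at propoxy, stays open. On these data alone, it is also open whether the added carbons themselves matter, which a terminal amine or carboxylic acid on the same propoxy chain could help to test.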